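The Same Methoxy Step Seen Twice in One Series

The source may hold more compounds than are shown below. What is called first, only, known or untested is meant among the compounds shown, and "the series" means these compounds.

Three compounds were measured in a functional assay on A498 cells (Homo sapiens) for cytotoxicity, read by sulforhodamine B assay, with a stated time of 48 h, tested at 0.1 uM (on this read-out higher numbers stand for a weaker effect at the one concentration tested and lower numbers for a stronger effect), and gave the following numbers.

Compound 1 `COc1cc(-c2cc(/C=C/C(=O)c3ccc(N)cc3)[nH]n2)cc(OC)c1OC` 85%
Compound 2 `COc1ccc(C(=O)/C=C/c2cc(-c3cc(OC)c(OC)c(OC)c3)n[nH]2)cc1OC` 86%
Compound 3 `COc1ccc(-c2cc(/C=C/C(=O)c3ccc(N)cc3)[nH]n2)cc1OC` 80%

All three numbers lie within the scatter of one another, so none of the compounds can be called stronger or weaker than the others in this assay. The step of a number 5 percentage points higher from compound 3 to compound 1 (within the scatter) belongs to the change (methoxy in place of hydrogen on an aromatic carbon). The step of a number 1 percentage points higher from compound 1 to compound 2 (within the scatter) belongs to the change of 3,4-dimethoxyphenyl in place of 4-aminophenyl on a carbonyl carbon. The difference between the core of compound 2 and the core of compound 3 is not broken down here.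

Compound 4 `COc1cc(C(=O)/C=C/c2cc(-c3cc(OC)c(OC)c(OC)c3)n[nH]2)cc(OC)c1OC` has not been measured. It differs from compound 2 by methoxy in place of hydrogen on an aromatic carbon, and the surroundings of the place are the same word for word as in the change from compound 3 to compound 1, so this is the same change. Because a number 5 percentage points higher from compound 3 to compound 1 (within the scatter) stayed within the scatter, the expected step of a number 3 percentage points higher from compound 2 to compound 4 (within the scatter) is estimated to be of similar small size. Compound 4 is therefore expected to give 89% in this assay, with a range from 78% to 98%.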

Compound 4, a percentage reported as activity, at one concentration (the size of the read-out at that concentration, not a potency): 90%
For compound 4 the middle estimate is 1 percentage points below the measured one; the range from low to high includes it.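

In this assay, methoxy in place of hydrogen on an aromatic carbon gives a number 4 percentage points higher from compound 2 to compound 4 (within the scatter), and this can be set beside the same change on the other core: the same change on two cores in this assay, a number 5 percentage points higher (within the scatter) from compound 3 to compound 1 and a number 4 percentage points higher (within the scatter) from compound 2 to compound 4, 1 percentage points apart, within the scatter of two such steps. In this series, then, the change behaves alike on both cores, with neither step distinguishable from the scatter and no difference between the two steps beyond it. This does not show that the methoxy group has an effect of its own in this read-out, and the agreement covers only these two cores at a single tested concentration.

From the compounds shown here alone, it remains open whether a different group at this place on the aromatic ring, such as a carboxylic acid, a fluorine atom or a longer alkoxy chain, would give a step beyond the scatter. Going by these compounds, it also remains open whether the two methoxy steps would still agree at other concentrations, where the compounds might separate more clearly.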